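Ether chain variation on the shared core

The source may hold more compounds than are shown below. What is called first, only, known or untested is meant among the compounds shown, and "the series" means these compounds.

Compound 2 `Cc1cc(OCC(C)C)cc(C)c1-c1cccc(COc2ccc(OCC(=O)O)c(F)c2)c1` carries an isobutoxy chain on the shared core; in a functional assay on CHO cells for agonist activity at Free fatty acid receptor 1 (Homo sapiens), read by FLIPR and calcium flux (a higher number here means that more compound is needed for the effect, a lower number that less compound is needed), compound 2 stands as "not determined" (no result reported), and compound 1 `COCCCOc1cc(C)c(-c2cccc(COc3ccc(OCC(=O)O)c(F)c3)c2)c(C)c1` in this assay likewise stands as "not determined" (no result reported). Among the compounds with values here, the only measured entry is compound 3 `Cc1cc(O)cc(C)c1-c1cccc(COc2ccc(OCC(=O)O)c(F)c2)c1`, which in this assay gives 110 nM. Compound 4 `COCCOc1cc(C)c(-c2cccc(COc3ccc(OCC(=O)O)c(F)c3)c2)c(C)c1` differs from compound 2 as follows: methoxymethyl in place of isopropyl on a saturated chain carbon bound to an oxygen on an aromatic ring. Within the data shown here, no measured pair shares this change, so the size of the step from compound 2 to compound 4 in this assay is unknown, and nothing argues for a shift beyond the usual scatter in either direction. Given that compound 3 gives 110 nM, compound 4 is expected at about 100 nM, with a range from 30 nM to 400 nM.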

Compound 4, half-maximal effective concentration: 104 nM
Beside the measured number, compound 4's estimate is 1.0-fold (0.02 log units) below it, within the range that was stated.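

In this assay the oxygen on the aromatic ring now has its first readable step, with 2-methoxyethyl in place of hydrogen giving a 1.1-fold lower number from compound 3 to compound 4 (0.02 log units; within the scatter) and so leaving the two compounds within the scatter of each other. Steps involving compound 1 or compound 2 cannot be read, so isobutoxy to 2-methoxyethoxy still has no size. No measured property bears on this result. Still open, as far as these compounds go, is how an amine, a carboxylic acid or a longer chain on an oxygen on an aromatic ring would read in this assay on the shared core.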